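Bromine out, fluorine in: a ketone ring swap

A few compounds are considered here, and "the series" means these few. Any claim that something is new, unique, unknown or untested is made for them only; others in the source may bear on it.

Compound 3 `COc1cc(OC)c(C(=O)c2ccccc2Br)c(O)c1CN1CCCC1` gives 100% in a functional assay on THP-1 cells (Homo sapiens) for inhibition, read by ELISA, with stated times of 30 min and 24 h, tested at 10 uM (a higher number here means a stronger effect of the compound at the concentration tested, a lower number a weaker effect), the highest of the three measured values. Compound 1 `COc1cc(OC)c(C(=O)c2ccccc2F)c(O)c1CN1CCCC1` gives 87%, and compound 2 `COc1cc(OC)c(C(=O)c2cccc(F)c2)c(O)c1CN1CCCCC1` gives 87% in this assay. Going by the values given here, the one measured step that touches this part of the molecule is a number 13 percentage points higher from compound 1 to compound 3 (beyond the scatter).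

Compound 4 `COc1cc(OC)c(C(=O)c2cccc(F)c2)c(O)c1CN1CCCC1` differs from compound 3 in one place: 3-fluorophenyl in place of 2-bromophenyl on a carbonyl carbon. This undoes the bromine gain of the measured step and at the same time moves to a 3-fluorophenyl, the same group that compound 2 carries on its carbonyl carbon together with a different amine ring. Since compound 2 sits at 87% and the step of a number 13 percentage points higher from compound 1 to compound 3 (beyond the scatter) was modest, a modest fall is expected here, back toward the level of compound 1 and compound 2. The expected step is a number 13 percentage points lower from compound 3 to compound 4 (beyond the scatter). Compound 4 is therefore estimated at 87% in this assay, with a plausible range from 75% to 97%.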

Compound 4, a percentage reported as activity, at one concentration (the size of the read-out at that concentration, not a potency): 93%
Beside the measured number, compound 4's estimate is 6 percentage points below it; measured number inside the range.
By their numbers in this assay, from the lowest: compounds 1, 2, 4 and 3 (each within the scatter of the next, the first and the last beyond it).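

In this assay, 3-fluorophenyl on the carbonyl carbon holds up against 2-bromophenyl, with a number 7 percentage points lower from compound 3 to compound 4 (within the scatter), so the bromine of compound 3 is not required for a read-out in this range. The two fluorophenyl groups are not separated either, with a number 6 percentage points higher from compound 1 to compound 4 (within the scatter), and the amine change gives a number 6 percentage points higher from compound 2 to compound 4 (within the scatter), which leaves pyrrolidin-1-yl and piperidin-1-yl unresolved in this pair. Nothing available here explains these results.

Open, on these data alone, is how a bromophenyl carrying its bromine where compound 4 carries its fluorine would read, which would separate the choice of halogen from its place on the ring. Also open, as far as these compounds go, is whether a morpholine or a dimethylamine could take the place of the pyrrolidin-1-yl group, and how these compounds would compare at other concentrations, which a single tested concentration cannot show.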